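From isopropyl to isobutyl: a mouse dose estimate

The source may hold more compounds than are shown below. What is called first, only, known or untested is meant among the compounds shown, and "the series" means these compounds.

Compound 1 `CNC(=O)[C@@H](C)NCc1ccc(OCc2ccccc2)cc1`: 40.5 mg/kg
Compound 2 `CNC(=O)[C@H](C)NCc1ccc(OCc2ccccc2)cc1`: 8.4 mg/kg
Compound 3 `CNC(=O)[C@H](NCc1ccc(OCc2ccccc2)cc1)C(C)C`: 112 mg/kg

In a functional assay on the whole organism with Mus musculus as the target (a lower number here means that less compound is needed, a higher number that more compound is needed for the effect), compound 3 has the highest number of the three. The next structure, compound 4 `CNC(=O)[C@@H](CC(C)C)NCc1ccc(OCc2ccccc2)cc1`, carries isobutyl in place of isopropyl on a saturated chain carbon bound to an amine nitrogen and a carbonyl carbon.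

The closest guide is the earlier enlargement of that group with the configuration as drawn kept, which gave a 2.8-fold higher number from compound 1 to compound 3 (0.44 log units; beyond the scatter). The larger 13-fold higher number from compound 2 to compound 3 (1.12 log units; beyond the scatter) also includes the configuration change seen in a 4.8-fold lower number from compound 1 to compound 2 (0.68 log units; beyond the scatter), so it bears less directly. Compounds 3 and 4 are drawn alike in this respect, so a small rise in this assay is expected, perhaps not beyond the scatter.

The expected change is a 1.3-fold higher number from compound 3 to compound 4 (0.13 log units; within the scatter). For compound 4 the estimate is 150 mg/kg, with an expected range of 65 mg/kg to 320 mg/kg.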

Compound 4, dose for half-maximal effect: 192 mg/kg
For compound 4 the middle estimate is 1.3-fold (0.11 log units) below the measured one, and the stated range covers the measured number.
By their numbers in this assay, from the lowest: compound 2; then compound 1; then compounds 3 and 4 (each within the scatter of the next).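

In this assay, replacing isopropyl with isobutyl gives a 1.7-fold higher number from compound 3 to compound 4 (0.23 log units; within the scatter), so this further enlargement, unlike the earlier one from methyl, cannot be told apart from repeat measurements. Measured from the methyl compound, the isobutyl group still gives a 4.7-fold higher number from compound 1 to compound 4 (0.68 log units; beyond the scatter), which leaves compound 3 and compound 4 both clearly above compound 1.

Still open, from the compounds shown here alone, is how a longer chain or an amine on this carbon would read. Also open, going by these compounds, is whether reversing the configuration of compound 4 would shift its number, as configuration alone did for the methyl pair: the fact that compounds 1 and 2 differ only in the configuration as drawn.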